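This account rests on a few compounds, and the source may have more. Where it says the series, first, only, none or still open, it means among the compounds named here.

Working notes on the series, in a functional assay on HCT-116 cells (Homo sapiens) for antiproliferative activity, read by sulforhodamine B assay, with a stated time of 72 h; on this read-out higher numbers stand for weaker inhibition and lower numbers for stronger inhibition.

Compound 1 `Cn1ncc(Cl)c1-c1cc(C(=O)N[C@@H]2CN[C@H](CCn3cncn3)C[C@H]2c2ccc(Cl)c(Cl)c2)oc1Cl` gives 560 nM in this assay. Going by the values given here, compound 2 `Cn1ncc(Cl)c1-c1cc(C(=O)N[C@@H]2CN[C@H](CC(=O)NC3CC3)C[C@H]2c2ccc(Cl)c(Cl)c2)oc1Cl` gives 740 nM, and the only step measured so far, a 1.3-fold higher number from compound 1 to compound 2 (0.12 log units; within the scatter), is a change on the chain rather than on the aryl group. Compound 3 `CNC(=O)C[C@@H]1C[C@@H](c2ccc(F)c(F)c2)[C@H](NC(=O)c2cc(-c3c(Cl)cnn3C)c(Cl)o2)CN1` gives 1100 nM, the highest of the three numbers, though each of its gaps to the others lies within the scatter, so no order among the three can be read from these values.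

Compound 4 `CNC(=O)C[C@@H]1C[C@@H](c2ccc(Cl)c(Cl)c2)[C@H](NC(=O)c2cc(-c3c(Cl)cnn3C)c(Cl)o2)CN1` is compound 3 with 3,4-dichlorophenyl in place of 3,4-difluorophenyl on a saturated ring carbon. Among the compounds with values here, no measured step bears directly on this change: the one step in hand, from compound 1 to compound 2, concerns the chain, and compound 1 differs from compound 3 in two places, so their two values can only be set side by side. Those two values, together with compound 2, show that the 3,4-dichlorophenyl analogues so far sit near the lower end of the range seen. The expected step, a 1.7-fold lower number from compound 3 to compound 4 (0.23 log units; within the scatter), is therefore a small one toward a lower number, not clearly beyond the scatter. Compound 4 is estimated at 650 nM, with a range of 300 nM to 1400 nM.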

Compound 4, half-maximal inhibitory concentration: 450 nM
Compound 4: the middle estimate sits 1.4-fold (0.16 log units) above what was measured; the measured number falls inside the stated range.
By their numbers in this assay, from the lowest: compounds 4, 1, 2 and 3 (each within the scatter of the next, the first and the last beyond it).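

In this assay, going by these compounds alone, the change to 3,4-dichlorophenyl in place of 3,4-difluorophenyl on a saturated ring carbon, next to the ring atom that bears a large group, gives a 2.4-fold lower number from compound 3 to compound 4 (0.39 log units; beyond the scatter), the first step at this position and a modest one that clears the scatter. On the chain, methyl in place of cyclopropyl on an amide-type nitrogen gives a 1.6-fold lower number from compound 2 to compound 4 (0.22 log units; within the scatter), and methylcarbamoyl in place of (1H-1,2,4-triazol-1-yl)methyl gives a 1.2-fold lower number from compound 1 to compound 4 (0.09 log units; within the scatter); both steps lie within the scatter, so with 3,4-dichlorophenyl held constant, these chains cannot be told apart on this read-out. No measured property of either aryl group is at hand to set beside the step.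

From the compounds shown here alone, the 3,4-difluorophenyl group appears here only with the (methylcarbamoyl)methyl chain, so whether the aryl step carries over to the chains of compound 1 and compound 2 remains open. Also open, going by these compounds, is how a 3,4-dimethylphenyl or an unsubstituted phenyl at this ring carbon, or a carboxylic acid or primary amine at the end of the chain, would stand against compound 4.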